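Swapping Heteroaryl Groups Across Two Chain Lengths

A few compounds are considered here, and "the series" means these few. Any claim that something is new, unique, unknown or untested is made for them only; others in the source may bear on it.

Compound 1 `CCCCCCCCCCCCCCNC(=O)[C@@H](NC(=O)c1cc2ccccc2o1)[C@@H](C)O` gives 23400 nM in a functional assay on HepG2 cells (Homo sapiens) for cytotoxicity, read by MTT assay, with a stated time of 48 h; on this read-out lower numbers stand for stronger inhibition and higher numbers for weaker inhibition. Compound 2 `CCCCCCCCCCCCCCNC(=O)[C@@H](NC(=O)c1nccc2ccccc12)[C@@H](C)O` gives 28600 nM in this assay. For compound 3 `CCCCCCCCCCCCCCCCCCNC(=O)[C@@H](NC(=O)c1cc2ccccc2o1)[C@@H](C)O` only a limit of the assay is known, > 200000 nM.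

Compound 1 and compound 2 differ by isoquinolin-1-yl in place of 1-benzofuran-2-yl on a carbonyl carbon, and this change gives a 1.2-fold higher number from compound 1 to compound 2 (0.09 log units; within the scatter). Compound 3 differs from compound 1 by butyl in place of hydrogen on a saturated chain carbon, ten or more bonds along the chain from an amide-type nitrogen, and that step reads an at least 8.5-fold higher number from compound 1 to compound 3 (0.93 log units; beyond the scatter). Within the data shown here, compound 4 `CCCCCCCCCCCCCCCCCCNC(=O)[C@@H](NC(=O)c1nccc2ccccc12)[C@@H](C)O` has not been measured yet; it differs from compound 3 by isoquinolin-1-yl in place of 1-benzofuran-2-yl on a carbonyl carbon, the same change at the same place as the one between compound 1 and compound 2. Because compound 3 sits at the limit of > 200000 nM in this assay, at which 1 of the 3 values shown sits, and the earlier swap stayed within the scatter, compound 4 is expected to remain near that limit, with an expected step that the limit leaves unreadable from compound 3 to compound 4. The estimate for compound 4 is 250000 nM, between 100000 nM and 600000 nM.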

Compound 4, half-maximal inhibitory concentration: 96900 nM
For compound 4 the middle estimate is 2.6-fold (0.41 log units) above the measured one; the measured number lies below the stated range.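

In this assay, putting isoquinolin-1-yl in place of 1-benzofuran-2-yl on the longer chain gives an at least 2.0-fold lower number from compound 3 to compound 4 (0.31 log units; beyond the scatter), while lengthening the chain on the isoquinolin-1-yl compounds gives a 3.4-fold higher number from compound 2 to compound 4 (0.53 log units; beyond the scatter), the same direction as lengthening it on the 1-benzofuran-2-yl compounds. Compound 3 has only a limit of the assay, > 200000 nM. The swap on the longer chain therefore has no exact size, and these compounds do not show whether its effect truly depends on chain length: the same change on two cores in this assay, a 1.2-fold higher number (0.09 log units; within the scatter) from compound 1 to compound 2 and an at least 2.0-fold lower number (0.31 log units; beyond the scatter) from compound 3 to compound 4; the limit leaves it open whether they differ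

The compounds shown leave open what a chain longer than that of compound 4 would do in this assay. They also leave open whether an amine or a carboxylic acid in place of the isoquinolin-1-yl group would follow the same trend.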